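Two stereo elements change from compound 2 to compound 3

A few compounds are considered here, and "the series" means these few. Any claim that something is new, unique, unknown or untested is made for them only; others in the source may bear on it.

Compound 1 `Cc1c(C(=O)OC[C@H]2O[C@H](O)[C@H](O)[C@@H](O)[C@H]2O)nnn1Cc1ccccc1`: 25600000 nM
Compound 2 `Cc1c(C(=O)O[C@H]2[C@@H](O)[C@H](O)O[C@H](CO)[C@H]2O)nnn1Cc1ccccc1`: 1440000 nM

In an ADME assay on Vero cells (Chlorocebus sabaeus) for cytotoxicity, read by MTT assay, with a stated time of 72 h (a lower number here means that less compound is tolerated, a higher number that more compound is tolerated), compound 2 gives 1440000 nM, the lower of the two numbers, and the gap to compound 1 at 25600000 nM lies beyond the scatter. Compound 3 `Cc1c(C(=O)O[C@H]2[C@H](O)[C@@H](CO)OC(O)[C@@H]2O)nnn1Cc1ccccc1` is related to compound 2 as follows: the two compounds have the same atoms and bonds; at least one stereo element is drawn with a configuration in one of them and without one in the other: 2 of 5 stereo elements differ; a stereocentre at a saturated ring carbon is drawn R in compound 2 and S in compound 3; a stereocentre at a saturated ring carbon is drawn R in compound 2 and without a configuration in compound 3. For the measured compounds named here, no measured pair shows what a change of this kind does, so no step beyond the scatter is expected in this assay. The expected 1.7-fold higher number from compound 2 to compound 3 (0.24 log units; within the scatter) is an uncertain figure. The range stays wide on the upper side, as compound 1 reaches 25600000 nM. For compound 3 the estimate is 2500000 nM, with an expected range of 700000 nM to 12000000 nM.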

Compound 3, half-maximal cytotoxic concentration: 1800000 nM
For compound 3 the middle estimate is 1.4-fold (0.14 log units) above the measured one, within the range that was stated.
By their numbers in this assay, from the lowest: compounds 2 and 3 (each within the scatter of the next); then compound 1.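

In this assay, for the compounds shown here, this is the first pair of compounds that differ only in stereo elements, and it gives a 1.3-fold higher number from compound 2 to compound 3 (0.10 log units; within the scatter). Together, the two altered saturated ring carbons therefore leave the number within the scatter. The step cannot be tied to a defined configuration at either carbon because of one feature of the drawings: the fact that one of compounds 2 and 3 is drawn with a defined configuration and the other without, at the place where they differ

On these data alone, the effect of each stereocentre alone remains open, as does the effect of a fully defined configuration at both. Also open, as far as these compounds go, is whether an amine on the saturated ring would leave the number within the scatter.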